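The compounds below may be only part of what the source reports. "The series", "measured", "known", "first", "only" and "open" are said of these compounds alone.

Measured so far:
compound 1 `O=c1cc(CSC(=S)N2CCCC2)oc2ccccc12` gives 35800 nM
compound 2 `O=c1cc(CSC(=S)N2CCCC2)oc2cc(Cl)ccc12` gives > 25000 nM, which is a limit of the assay

For the measured compounds named here, in a functional assay on MCF7 cells (Homo sapiens) for antiproliferative activity, read by MTT assay, with a stated time of 72 h (on this read-out lower numbers stand for stronger inhibition and higher numbers for weaker inhibition), compound 1 gives 35800 nM, the only plain number among the two values shown. Compound 2 is reported only as a limit, > 25000 nM, and the limit of > 25000 nM in this assay, at which 1 of the 2 values shown sits, is where one of the two values shown sits. Going by the values given here, the single measured step, a step that the limit leaves unreadable from compound 1 to compound 2, a chloro in place of hydrogen on an aromatic carbon, therefore cannot be given a size.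

Compound 3 `CC(C)N(C(=S)SCc1cc(=O)c2ccccc2o1)C(C)C` differs from compound 1 in one place: diisopropylamino in place of pyrrolidin-1-yl on a thiocarbonyl carbon. No measured step touches the group on the thiocarbonyl carbon, so there is nothing in the numbers shown that points to a shift in either direction for this change; the one step that was measured concerns a different place and is unreadable. On that basis the expectation for compound 3 is a value close to that of compound 1, with a 1.0-fold lower number from compound 1 to compound 3 (0.01 log units; within the scatter) expected to stay within the usual scatter. Compound 3 is thus estimated at 35000 nM, with a range from 12000 nM to 100000 nM.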

Compound 3, half-maximal inhibitory concentration: 31700 nM
Compound 3: the middle estimate sits 1.1-fold (0.04 log units) above what was measured; the range from low to high includes it.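

In this assay, putting diisopropylamino in place of pyrrolidin-1-yl on the thiocarbonyl carbon gives a 1.1-fold lower number from compound 1 to compound 3 (0.05 log units; within the scatter). For the compounds shown here, this is the first step that can be read, and it shows that at this place an open group with no ring and more heavy atoms can stand in for the five-membered ring while the number stays within the usual scatter of repeated measurements. The values shown offer no reason for this outcome.

From the compounds shown here alone, both of these groups are built only of carbon and one nitrogen, so it remains open whether a group of another kind on the thiocarbonyl carbon, such as a morpholine ring, a piperazine ring or a longer chain on the nitrogen, would move the number beyond the scatter. Compound 2 is reported only as a limit and its step cannot be read, which also leaves open what chloro in place of hydrogen on an aromatic carbon does to the core of compound 1.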